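The source may report more compounds than this note shows. Statements on the series, on what has been measured and on what is new or still open speak of the compounds shown alone.

Series notes. Compound 1 `CC(C)CCn1nc(-c2cccs2)c(O)c(C2=NS(=O)(=O)c3cc(OC(C)(C)C(N)=O)ccc3N2)c1=O` gives 0.35 h in an in vitro ADME assay on microsomes from liver (Homo sapiens) for metabolic stability, tested at 5 uM; a lower number here means that the compound disappears faster, a higher number that the compound lasts longer. Compound 2 `CC(C)CCn1nc(-c2cccs2)c(O)c(C2=NS(=O)(=O)c3cc(OCC(=O)NO)ccc3N2)c1=O` reaches a limit in this assay, reported as > 1 h (the limit of > 1 h in this assay, at which 1 of the 3 values shown sits). Compound 3 `CC(C)CCn1nc(-c2cccs2)c(O)c(C2=NS(=O)(=O)c3cc(OCC#N)ccc3N2)c1=O` gives 0.25 h in this assay, the lowest of the two numbers shown, with compound 1 nearest: the step of a 1.4-fold lower number from compound 1 to compound 3 (0.15 log units; within the scatter) stays within the usual scatter, whereas an at least 4.0-fold lower number from compound 2 to compound 3 (0.60 log units; beyond the scatter) lies beyond it. Compound 4 `CC(C)CCn1nc(-c2cccs2)c(O)c(C2=NS(=O)(=O)c3cc(CCC(N)=O)ccc3N2)c1=O` is not yet measured. The change is 2-carbamoylethyl in place of cyanomethoxy on an aromatic carbon. For the measured compounds named here, two measured steps touch on it. The step of an at least 4.0-fold lower number from compound 2 to compound 3 (0.60 log units; beyond the scatter) exchanges a hydroxycarbamoyl group for a cyano group and is a clear drop. The step of a 1.4-fold lower number from compound 1 to compound 3 (0.15 log units; within the scatter) exchanges a carbamoyl-bearing group for a cyanomethyl group and is small. The entering 2-carbamoylethyl carries a carbamoyl group, as did the group lost in a 1.4-fold lower number from compound 1 to compound 3 (0.15 log units; within the scatter). For compound 4 a small rise is therefore expected, a 1.6-fold higher number from compound 3 to compound 4 (0.20 log units; within the scatter), not clearly beyond the scatter. For compound 4 the estimate in this assay is 0.4 h, between 0.2 h and 0.9 h.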

Compound 4, half-life: > 1 h
Compound 4: only a limit was reported; the forecaster's own chance of this, stated with the estimate: 10%; middle value at least 2.5-fold (0.39 log units) away from the limit.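

In this assay, an at least 4.0-fold higher number from compound 3 to compound 4 (0.60 log units; beyond the scatter) and an at least 2.8-fold higher number from compound 1 to compound 4 (0.45 log units; beyond the scatter), so a carbamoyl group alone does not settle the read-out: the 1-carbamoyl-1-methylethoxy group carries one too. Compounds 1, 2 and 3 all hold their side chain through an oxygen on the aromatic ring, and compound 4 now shows that a chain bound directly to the aromatic carbon can also reach the top of the range. Compound 4 ends at a limit of the assay, and compound 2 shares it: the limit of > 1 h in this assay, at which 2 of the 4 values shown sit.

On these data alone, the step between these two compounds cannot be read, so their order stays unknown. Also open, as far as these compounds go, is whether the carbon link or the carbamoyl group carries the rise, and whether a carboxylic acid or an amine at the end of the same chain would keep the half-life.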